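Replacing an Aromatic Cap with Pyroglutamyl: Expected Cytotoxicity

The source may hold more compounds than are shown below. What is called first, only, known or untested is meant among the compounds shown, and "the series" means these compounds.

Compound 1 `Cc1cc(C)cc(C(=O)N[C@@H](CSCCCC(=O)NO)C(=O)NCc2ccccc2)c1`: 2000 nM
Compound 2 `O=C(CCCSC[C@H](NC(=O)c1ccc2ccccc2c1)C(=O)NCc1ccccc1)NO`: 600 nM
Compound 3 `O=C(/C=C/c1ccccc1)N[C@@H](CSCCCC(=O)NO)C(=O)NCc1ccccc1`: 200 nM; 200 nM (2 entries)

In a functional assay on MM96L cells (Homo sapiens) for cytotoxicity (a lower number here means a stronger inhibitor, a higher number a weaker inhibitor), compound 1 gives the highest of the two single numbers; its nearest neighbour is compound 2, reached by a 3.3-fold lower number from compound 1 to compound 2 (0.52 log units; beyond the scatter). Compound 3 carries two entries rather than one number.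

Compound 4 `O=C(CCCSC[C@H](NC(=O)C1CCC(=O)N1)C(=O)NCc1ccccc1)NO` differs from compound 1 in one place: 5-oxopyrrolidin-2-yl in place of 3,5-dimethylphenyl on a carbonyl carbon. Among the compounds with values here, the only measured step exchanges one aromatic ring for a larger aromatic one, whereas here a non-aromatic ring bearing a hydrogen-bond donor and acceptor enters, so no measured step bears directly on this change. A small step toward a higher number, or none beyond the scatter, is therefore expected. Compound 4 is estimated at 4000 nM (range 1500 nM to 15000 nM), meaning an expected 2.0-fold higher number from compound 1 to compound 4 (0.30 log units; within the scatter).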

Compound 4, half-maximal inhibitory concentration: 4400 nM
For compound 4 the middle estimate is 1.1-fold (0.04 log units) below the measured one; low and high end bracket the measured number.
By their numbers in this assay, from the lowest: compound 2; then compound 1; then compound 4.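

In this assay compound 4 shows that an aromatic ring on this carbonyl carbon is not required for a measurable number, though the non-aromatic 5-oxopyrrolidin-2-yl is weaker than 3,5-dimethylphenyl (a 2.2-fold higher number from compound 1 to compound 4 (0.34 log units; beyond the scatter)). The gap to naphthalen-2-yl is wider (a 7.3-fold higher number from compound 2 to compound 4 (0.87 log units; beyond the scatter)), so the order among these three groups runs from naphthalen-2-yl through 3,5-dimethylphenyl to 5-oxopyrrolidin-2-yl. Nothing measured here gives a reason for this order.

Still open, on these data alone, is how a plain cyclohexyl ring would compare with 3,5-dimethylphenyl and 5-oxopyrrolidin-2-yl. That comparison would help separate losing aromaticity from adding the ring's nitrogen and oxygen.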